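A few compounds are considered here, and "the series" means these few. Any claim that something is new, unique, unknown or untested is made for them only; others in the source may bear on it.

Compound 1 `Oc1cccc(-c2cc(-c3ccccc3F)cc(-c3ccccc3O)n2)c1`: in a functional assay on HeLa cells (Homo sapiens) for inhibition (on this read-out higher numbers stand for weaker inhibition and lower numbers for stronger inhibition), compound 1 gives 31100 nM.
Compound 2 `Oc1cccc(-c2cc(-c3ccc(F)cc3)cc(-c3ccccc3O)n2)c1`: in this assay compound 2 gives only a limit of the assay, > 50000 nM.
Compound 3 `Oc1ccccc1-c1cc(-c2cccc(C(F)(F)F)c2)cc(-c2ccccc2O)n1`: in this assay compound 3 gives only a limit of the assay, > 50000 nM.

Compound 3 therefore stands at the edge of what this assay can report, and it shares that position with one other compound, as the limit of > 50000 nM in this assay, at which 2 of the 3 values shown sit, shows; only compound 1 yields a number below the limit.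

Compound 4 `Oc1cccc(-c2cc(-c3cccc(C(F)(F)F)c3)cc(-c3ccccc3O)n2)c1` differs from compound 3 in one place: 3-hydroxyphenyl in place of 2-hydroxyphenyl on an aromatic carbon. Among the measured pairs, none changes the hydroxyphenyl group; the only measured step, an at least 1.6-fold higher number from compound 1 to compound 2 (0.20 log units; that floor lies within the scatter), concerns the fluorophenyl group on the shared core and is not beyond the scatter. It says nothing direct about the hydroxyphenyl exchange. Compounds 1 and 2 already carry a 3-hydroxyphenyl group and a 2-hydroxyphenyl group together, and neither reaches strong inhibition.

With compound 3 at a limit, the expected step of a number no higher from compound 3 to compound 4 (the limit leaves the size open) cannot be stated beyond the scatter in either direction. Compound 4 is therefore estimated at 50000 nM in this assay, with a range from 20000 nM to 120000 nM, and it is expected most likely to return only a limit again.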

Compound 4, half-maximal inhibitory concentration: 19500 nM
The estimate for compound 4 lay 2.6-fold (0.41 log units) above the measured number, and the stated range ends above it.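

In this assay, 3-hydroxyphenyl in place of 2-hydroxyphenyl on the aromatic carbon next to the ring nitrogen, with the 3-(trifluoromethyl)phenyl group unchanged, gives a change beyond the scatter, the first such change among the compounds shown: an at least 2.5-fold lower number from compound 3 to compound 4 (0.40 log units; beyond the scatter). The group at the other varied place also matters when the two hydroxyphenyl groups are held constant, with 3-(trifluoromethyl)phenyl in place of 4-fluorophenyl giving an at least 2.5-fold lower number from compound 2 to compound 4 (0.40 log units; beyond the scatter), whereas 3-(trifluoromethyl)phenyl in place of 2-fluorophenyl gives only a 1.6-fold lower number from compound 1 to compound 4 (0.20 log units; within the scatter), so that pair cannot be ordered. The two steps beyond the scatter give floors rather than full sizes, as each starts from a value that is only a limit: the limit of > 50000 nM in this assay, at which 2 of the 4 values shown sit.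

The compounds shown leave open whether the hydroxyl has to stay on a phenyl ring at this place, or whether a 4-hydroxyphenyl, a 3-aminophenyl or a 3-methoxyphenyl group would serve as well. They also leave open how the remaining 2-hydroxyphenyl group contributes, and whether a 3-hydroxyphenyl group in its place would lower the number further.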